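The compounds below may be only part of what the source reports. "The series", "measured", "known", "first", "only" and "open" are said of these compounds alone.

Working notes on the series. Compound 1 `COC(=O)[C@@]1(C)CC[C@@H]2C3=C1CC[C@@H](C)[C@]3(C)C[C@@H]1c3cc(Br)ccc3N[C@H]21` and compound 2 `COC(=O)[C@@]1(C)CC[C@@H]2C3=C1CC[C@@H](C)[C@]3(C)Cc1c2[nH]c2ccccc12` share a core; in a functional assay on HeLa cells (Homo sapiens) for inhibition, read by sulforhodamine B assay, with a stated time of 48 h (a higher number here means a weaker inhibitor of growth, a lower number a stronger inhibitor of growth), compound 1 gives 25000 nM, while compound 2 gives 3200 nM, the lower of the two numbers and a gap beyond the usual scatter. Compound 3 `COC(=O)[C@@]1(C)CC[C@@H]2C3=C1CC[C@@H](C)[C@]3(C)Cc1c2[nH]c2ccc(C)cc12` differs from compound 2 by methyl in place of hydrogen on an aromatic carbon. For the measured compounds named here, no measured pair shows this change, so the step of a 1.3-fold lower number from compound 2 to compound 3 (0.11 log units; within the scatter) is expected to stay within the scatter in either direction. In this assay compound 3 is estimated at 2500 nM, with a range of 900 nM to 7000 nM.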

Compound 3, concentration for 50% growth inhibition: 11000 nM
Compound 3: the middle estimate sits 4.4-fold (0.64 log units) below what was measured; the measured number lies above the stated range.
By their numbers in this assay, from the lowest: compound 2; then compound 3; then compound 1.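

In this assay, this aromatic carbon of the shared core does not tolerate substitution freely: methyl in place of hydrogen gives a 3.4-fold higher number from compound 2 to compound 3 (0.54 log units; beyond the scatter), so a single added carbon here is enough to raise the number beyond the scatter. For the compounds shown here, this is the only step read at this position, and nothing at hand accounts for its size. Going by these compounds, whether a methoxy group, an amine or a chlorine atom on the same carbon would also raise the number remains open, as does the effect of a longer chain such as ethyl.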